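The source may hold more compounds than are shown below. What is called first, only, known or untested is meant among the compounds shown, and "the series" means these compounds.

Measured so far:
compound 1 `CCCC(=O)Nc1c(C(O)(C(F)(F)F)C(F)(F)F)ccc2ccccc12` — 131 nM
compound 2 `CCC(CC)C(=O)Nc1c(C(O)(C(F)(F)F)C(F)(F)F)ccc2ccccc12` — 4340 nM
compound 3 `CC(C)CCC(=O)Nc1c(C(O)(C(F)(F)F)C(F)(F)F)ccc2ccccc12` — 49 nM

In an assay on LtK cells with ATP-sensitive inward rectifier potassium channel 11 (Homo sapiens) as the target (on this read-out lower numbers stand for an effect already at smaller amounts and higher numbers for an effect only at larger amounts of compound), compound 2 stands at the highest number of the three; the nearest step to it is a 33-fold higher number from compound 1 to compound 2 (1.52 log units; beyond the scatter), and the furthest is an 89-fold lower number from compound 2 to compound 3 (1.95 log units; beyond the scatter). Compound 4 `O=C(CCc1ccccc1)Nc1c(C(O)(C(F)(F)F)C(F)(F)F)ccc2ccccc12` is not yet measured. It differs from compound 2 by phenethyl in place of pentan-3-yl on a carbonyl carbon. Both measured steps bear on this: the branched pentan-3-yl gave the high number of compound 2, while unbranched chains in compound 1 and compound 3 gave far lower numbers. Phenethyl is likewise unbranched at the carbonyl carbon, so a large drop in number, a 29-fold lower number from compound 2 to compound 4 (1.46 log units; beyond the scatter), is expected. Compound 4 is therefore estimated at 150 nM, within 40 nM to 600 nM.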

Compound 4, half-maximal effective concentration: 1750 nM
For compound 4 the middle estimate is 12-fold (1.07 log units) below the measured one, and the stated range ends below it.
By their numbers in this assay, from the lowest: compound 3; then compound 1; then compound 4; then compound 2.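

In this assay, being unbranched at the carbonyl carbon does not by itself give a low number: phenyl at the end of the chain, in place of methyl (a 13-fold higher number from compound 1 to compound 4 (1.13 log units; beyond the scatter)) or isopropyl (a 36-fold higher number from compound 3 to compound 4 (1.55 log units; beyond the scatter)), raises it sharply. Phenethyl in place of pentan-3-yl brings only a modest gain (a 2.5-fold lower number from compound 2 to compound 4 (0.39 log units; beyond the scatter)), so the end of the chain matters as well as the branching. Nothing measured here accounts for the poorer result with phenyl at the chain end. Still open, going by these compounds, is whether cyclohexyl in place of that phenyl would bring the number back down. Also open, on these data alone, is whether a longer chain ending in isopropyl would go lower than compound 3.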